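The source may report more compounds than this note shows. Statements on the series, on what has been measured and on what is new or still open speak of the compounds shown alone.

Measured compounds:

Compound 1 `O=C(NNC(=O)c1ccc(Cl)cc1)c1ccncc1` — in an ADME assay on MT4 cells (Homo sapiens) for cytotoxicity (on this read-out lower numbers stand for higher toxicity in this test and higher numbers for lower toxicity in this test), compound 1 gives > 120 ug/mL, which is a limit of the assay and not a number.
Compound 2 `Cc1ccc(/C=N/N(C(=O)c2ccccc2)C(=O)c2ccncc2)cc1` — in this assay compound 2 gives 42 ug/mL.
Compound 3 `O=C(N/N=C/c1c[nH]c2ccccc12)c1ccncc1` — in this assay compound 3 gives 95 ug/mL.

Of the two numbers reported, compound 2 stands lowest; compound 3 sits higher, and the gap between them lies beyond the usual scatter. Compound 1 is recorded only as a limit, namely (the limit of > 120 ug/mL in this assay, at which 1 of the 3 values shown sits), so no number places it against the other two.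

Compound 4 `COc1cc(/C=N/N(C(=O)c2ccccc2)C(=O)c2ccncc2)ccc1O` has not yet been measured. It differs from compound 2 in a single place: 4-hydroxy-3-methoxyphenyl in place of 4-methylphenyl on a carbon with a double bond to nitrogen. Going by the values given here, no measured pair in this set differs in this way alone, so nothing measured tells the size of this step; the expectation rests on the structural change alone. In this assay the step of a 1.5-fold higher number from compound 2 to compound 4 (0.19 log units; within the scatter) is expected to be modest and toward a higher number, close to the edge of the scatter. Compound 4 is therefore estimated at 65 ug/mL, with a range from 28 ug/mL to 120 ug/mL.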

Compound 4, half-maximal cytotoxic concentration: 105 ug/mL
Beside the measured number, compound 4's estimate is 1.6-fold (0.21 log units) below it; the measured number falls inside the stated range.
By their numbers in this assay, from the lowest: compound 2; then compounds 3 and 4 (each within the scatter of the next). At a limit, above all of these: compound 1.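

The set now holds a measured step at this position: in this assay, 4-hydroxy-3-methoxyphenyl in place of 4-methylphenyl on a carbon with a double bond to nitrogen gives a 2.5-fold higher number from compound 2 to compound 4 (0.40 log units; beyond the scatter), a modest move toward lower toxicity in this test. The earlier compounds shown here could not show that this one exchange, with the rest of the structure unchanged, moves the number past the usual scatter. Nothing measured here gives a cause for this step.

The hydroxy and the methoxy enter together, so the step cannot be divided between them, and a ring carrying only one of the two would be needed to do so. As far as these compounds go, how a dimethylamino group or a carboxylic acid on this phenyl ring would read in this assay also remains open.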